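The source may hold more compounds than are shown below. What is called first, only, known or untested is meant among the compounds shown, and "the series" means these compounds.

Measured so far:

Compound 2 `Nc1ccccc1NC(=O)c1ccc(CSC(=S)N2CCN(c3ccccc3)CC2)cc1` — 88.6%
Compound 3 `CN(C(=S)SCc1ccc(C(=O)Nc2ccccc2N)cc1)c1cccnc1` — 87.7%
Compound 1 `Nc1ccccc1NC(=O)c1ccc(CSC(=S)N2CCN(C(c3ccccc3)c3ccccc3)CC2)cc1` — 8.4%

Of the compounds shown here, three have been tested in a functional assay on A-375 cells (Homo sapiens) for antiproliferative activity, read by CCK-8 assay, with a stated time of 72 h, tested at 8 uM; a higher number here means a stronger effect of the compound at the concentration tested, a lower number a weaker effect. Compound 2 gives the highest of the three numbers. Its nearest neighbour is compound 3, whose value lies within the usual scatter of this assay, so the two cannot be placed in any order. Compound 1 stands far lower, and that gap lies well beyond the scatter, so compound 2 and compound 3 clearly act more strongly than compound 1 at the tested concentration.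

The next compound, compound 4 `N#Cc1ccc(N2CCN(C(=S)SCc3ccc(C(=O)Nc4ccccc4N)cc3)CC2)cc1`, is compound 2 with one change:

cyano in place of hydrogen on an aromatic carbon

For the measured compounds named here, no pair of measured compounds differs by this kind of change, so there is no measured step to lean on. The expectation rests on compound 2 alone, whose value in this assay already sits near the top of what a percentage inhibition can reach. For that reason the step from compound 2 to compound 4 is expected to be small, with no clear direction, and to stay within the scatter: a number 3.6 percentage points lower from compound 2 to compound 4 (within the scatter). Compound 4 is therefore expected to give about 85% in this assay, within a range from 65% to 97%.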

Compound 4, a percentage reported as inhibition, at one concentration (the size of the read-out at that concentration, not a potency): 62.9%
Compound 4: the middle estimate sits 22.1 percentage points above what was measured, and the stated range ends above it.
By their numbers in this assay, from the lowest: compound 1; then compound 4; then compounds 3 and 2 (each within the scatter of the next).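

In this assay, the change from phenyl to 4-cyanophenyl brings a number 25.7 percentage points lower from compound 2 to compound 4 (beyond the scatter), so the aromatic carbon para to a large group is a place where a small addition can alter the reading. The high number of compound 2 therefore did not mean that this ring would accept any added group without a clear change, since a cyano group of only 2 heavy atoms was enough to lower the reading, although compound 4 still gives 62.9%. Nothing measured here explains why the number falls.

As far as these compounds go, with a single added group at a single position, it remains open whether the drop is specific to cyano or would follow from other groups placed on the same carbon. From the compounds shown here alone, a fluorine atom, a methoxy group or an amine at that carbon could help separate those two readings, while potency stays open too, as this read-out gives the size of the effect at one concentration only.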